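A few compounds are considered here, and "the series" means these few. Any claim that something is new, unique, unknown or untested is made for them only; others in the source may bear on it.

Measured so far:
compound 1 `CC1(C)[C@H]2CC[C@]1(C)N(Cc1cn(-c3cccc(Cl)c3)nn1)C(=O)C2` gives 60 nM;
compound 2 `CC1(C)[C@H]2CC[C@]1(C)N(Cc1cn(-c3cccc(O)c3)nn1)C(=O)C2` gives 180 nM;
compound 3 `CC1(C)[C@H]2CC[C@]1(C)N(Cc1cn(-c3ccc(C#N)cc3)nn1)C(=O)C2` gives 140 nM.

All three were tested in a functional assay on A549 cells (Homo sapiens) for inhibition, read by MTT assay, with a stated time of 24 h; a higher number here means a weaker inhibitor, a lower number a stronger inhibitor. Compound 3 sits second highest of these three numbers: the step of a 1.3-fold lower number from compound 2 to compound 3 (0.11 log units; within the scatter) lies within the scatter, while the step of a 2.3-fold higher number from compound 1 to compound 3 (0.37 log units; beyond the scatter) is the only one beyond the scatter. Compound 4 `COc1cccc(-n2cc(CN3C(=O)C[C@@H]4CC[C@@]3(C)C4(C)C)nn2)c1` carries the change (3-methoxyphenyl in place of 4-cyanophenyl on an aromatic nitrogen). The two steps that bear on it, a 2.3-fold higher number from compound 1 to compound 3 (0.37 log units; beyond the scatter) and a 1.3-fold lower number from compound 2 to compound 3 (0.11 log units; within the scatter), show that swapping the aryl group on the aromatic nitrogen moves the number only modestly. The step of a 1.4-fold lower number from compound 3 to compound 4 (0.15 log units; within the scatter) is therefore expected to stay small, likely a somewhat lower number. Compound 4 is estimated at 100 nM, within 40 nM to 250 nM.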

Compound 4, half-maximal inhibitory concentration: 240 nM
Estimate against measurement, compound 4: 2.4-fold (0.38 log units) below; low and high end bracket the measured number.
By their numbers in this assay, from the lowest: compound 1; then compounds 3, 2 and 4 (each within the scatter of the next).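

In this assay, methyl in place of hydrogen on the oxygen gives a 1.3-fold higher number from compound 2 to compound 4 (0.12 log units; within the scatter), so capping the hydroxy group changes nothing that can be read. The step of a 1.7-fold higher number from compound 3 to compound 4 (0.23 log units; within the scatter) also stays within the scatter, leaving compounds 2, 3 and 4 indistinguishable. Methoxy in place of chloro, by contrast, gives a 4.0-fold higher number from compound 1 to compound 4 (0.60 log units; beyond the scatter), and compound 1 alone stands apart as the strongest inhibitor of the four.

Nothing shown explains why chloro differs from the other groups. From the compounds shown here alone, whether an amine or a carboxylic acid in place of chloro would keep the lower number remains open.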